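Methoxy for fluoro on the aryl ring of a pyrazole thiourea

The source may hold more compounds than are shown below. What is called first, only, known or untested is meant among the compounds shown, and "the series" means these compounds.

Compound 1, `Cc1ccc(NC(=S)NC(=O)c2cn(-c3ccccc3)nc2-c2ccc(F)cc2)cc1`, gives in a functional assay on MCF7 cells (Homo sapiens) for inhibition, read by CCK-8 assay, with a stated time of 48 h (a lower number here means a stronger inhibitor, a higher number a weaker inhibitor), a value of 5440 nM.
Compound 2, `O=C(NC(=S)Nc1ccc(F)cc1)c1cn(-c2ccccc2)nc1-c1ccc(F)cc1`, gives in this assay a value of 5610 nM.
Compound 3, `O=C(NC(=S)Nc1ccc(Cl)cc1)c1cn(-c2ccccc2)nc1-c1ccccc1`, gives in this assay a value of 6230 nM.

Compound 1 stands with the lowest of the three numbers, but its nearest neighbour is compound 2 and the gap to it is within the scatter, as is the gap to compound 3, so none of the three can be called stronger than the others. For the measured compounds named here, the one single-place step measured, a 1.0-fold higher number from compound 1 to compound 2 (0.01 log units; within the scatter), concerns the ring carried by the thiourea nitrogen and shows no movement beyond the scatter. Compound 3 differs from the others in more than one place and its value stands alongside theirs.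

Compound 4, `COc1ccc(-c2nn(-c3ccccc3)cc2C(=O)NC(=S)Nc2ccc(C)cc2)cc1`, differs from compound 1 in that (methoxy in place of fluoro on an aromatic carbon). Going by the values given here, no measured step touches this ring, so the only guide is the general flatness of the numbers. Compound 4 is therefore expected to give 5500 nM, between 2500 nM and 12000 nM, meaning an expected step of a 1.0-fold higher number from compound 1 to compound 4 (0.00 log units; within the scatter).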

Compound 4, half-maximal inhibitory concentration: 4630 nM
The estimate for compound 4 lay 1.2-fold (0.07 log units) above the measured number, within the range that was stated.
By their numbers in this assay, from the lowest: compounds 4, 1, 2 and 3 (each within the scatter of the next).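

In this assay, for the compounds shown here, the change from 4-fluorophenyl to 4-methoxyphenyl reads as a 1.2-fold lower number from compound 1 to compound 4 (0.07 log units; within the scatter) and is the only measured step at this ring. It shows that on this aromatic carbon, para to a large group, methoxy can take the place of fluoro without the number moving beyond the scatter, so this position joins the ring on the thiourea nitrogen in showing no measurable response so far. No evidence is available that bears on this result.

The compounds shown leave open whether an amine, a carboxylic acid or a longer chain such as butoxy at this place would move the number beyond the scatter. They also leave open whether the same change would stay as flat with a chloro group on the ring carried by the thiourea nitrogen.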